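A few compounds are considered here, and "the series" means these few. Any claim that something is new, unique, unknown or untested is made for them only; others in the source may bear on it.

Compound 2 `O/N=C(/Nc1cccc(Br)c1)c1ccc2occc2c1` gives 1100 nM in an assay on tissue (HeLa cells) for inhibition of Indoleamine 2,3-dioxygenase 1 (Homo sapiens), read by spectrophotometry (on this read-out lower numbers stand for stronger inhibition and higher numbers for weaker inhibition), the lowest of the three numbers available. Compound 1 `O/N=C(/Nc1ccccc1)c1ccc2occc2c1`, which lacks the bromo group, gives 19000 nM in this assay, and compound 3 `O/N=C(/Nc1ccc(F)c(Br)c1)c1ccc2occc2c1`, which carries an added fluoro group, gives 2600 nM in this assay. Compound 4 `CC(=O)c1cccc(N/C(=N/O)c2ccc3occc3c2)c1` differs from compound 2 by acetyl in place of bromo on an aromatic carbon. For the measured compounds named here, two measured steps bear on this change. The step of a 17-fold lower number from compound 1 to compound 2 (1.24 log units; beyond the scatter) shows a large gain on adding the bromo group, while the step of a 2.4-fold higher number from compound 2 to compound 3 (0.37 log units; beyond the scatter) shows a modest loss on adding a fluoro group. Going by the values given here, no measured pair shows an acetyl group at this place, so its own effect is unknown. Because the large step of a 17-fold lower number from compound 1 to compound 2 (1.24 log units; beyond the scatter) arose on adding the bromo group, removing that group and putting acetyl in its stead is expected to give a higher number, of moderate size and with wide uncertainty. Compound 4 is therefore expected to give 3500 nM in this assay, within a range from 900 nM to 14000 nM. This estimate corresponds to an expected step of a 3.2-fold higher number from compound 2 to compound 4 (0.50 log units; beyond the scatter).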

Compound 4, half-maximal inhibitory concentration: > 30000 nM
Compound 4 gave a limit, no number (the forecaster's own chance of this, stated with the estimate: 5%); middle value at least 8.5-fold (0.93 log units) from the limit.
By their numbers in this assay, from the lowest: compound 2; then compound 3; then compound 1. At a limit, above all of these: compound 4.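

In this assay compound 4 reads > 30000 nM, which is a limit and not a number: the limit of > 30000 nM in this assay, at which 1 of the 4 values shown sits. This shows that the place on the aromatic carbon is not simply tolerant of any group larger than hydrogen, since acetyl does not keep what bromo gave, with an at least 27-fold higher number from compound 2 to compound 4 (1.43 log units; beyond the scatter). Against hydrogen at the same place the reading is an at least 1.5-fold higher number from compound 1 to compound 4 (0.19 log units; that floor lies within the scatter), so acetyl shows none of the gain seen with bromo, though that floor does not show it doing worse than hydrogen.

The compounds shown hold no chloro, methyl or amine at this place, so it stays open whether the gain belongs to bromo alone or to a wider set of groups. From the compounds shown here alone, how far acetyl actually lies from hydrogen also stays open, as compound 4 has only a limit.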